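Swapping the ortho aryl group for a pyrrole ring

The compounds below may be only part of what the source reports. "The series", "measured", "known", "first", "only" and "open" are said of these compounds alone.

The series rests on a shared proline-amide core, seen in compound 1 `O=C(Nc1ccccc1)[C@@H]1CCCN1C(=O)CSc1nc2ccccc2[nH]1`, which in an assay on CHO cells for displacement of a labelled ligand from Orexin/Hypocretin receptor type 1 (Homo sapiens) (a higher number here means a weaker inhibitor, a lower number a stronger inhibitor), gives 1400 nM. Compound 3 `O=C(Nc1ccccc1-c1ccccc1)[C@@H]1CCCN1C(=O)CSc1nc2ccccc2[nH]1` gives 10 nM, and the step of a 140-fold lower number from compound 1 to compound 3 (2.15 log units; beyond the scatter) shows how much the group on that aromatic carbon can matter. For the measured compounds named here, compound 2 `COc1ccccc1-c1ccccc1NC(=O)[C@@H]1CCCN1C(=O)CCc1nc2ccccc2[nH]1` gives 86 nM, the second highest of the three numbers; it sits far below compound 1 and well above compound 3, though no single-point step links it to either.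

Compound 4 `O=C(Nc1ccccc1-n1cccc1)[C@@H]1CCCN1C(=O)CCc1nc2ccccc2[nH]1` differs from compound 2 by 1H-pyrrol-1-yl in place of 2-methoxyphenyl on an aromatic carbon, placed on an aromatic carbon of a six-membered aromatic ring of carbon only, ortho to a large group. Going by the values given here, the only measured step, from compound 1 to compound 3, concerns whether an aromatic group stands there at all, not which one; compound 4 keeps one. He therefore expects a step of a 1.4-fold lower number from compound 2 to compound 4 (0.16 log units; within the scatter) that stays near or within the scatter. His estimate for compound 4 is 60 nM, with a range from 15 nM to 250 nM.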

Compound 4, inhibition constant: 130 nM
The estimate for compound 4 lay 2.2-fold (0.34 log units) below the measured number, and the stated range covers the measured number.
By their numbers in this assay, from the lowest: compound 3; then compounds 2 and 4 (each within the scatter of the next); then compound 1.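

In this assay, putting 1H-pyrrol-1-yl in place of 2-methoxyphenyl gives a 1.5-fold higher number from compound 2 to compound 4 (0.18 log units; within the scatter) so the two groups cannot be told apart at this place, on an aromatic carbon of a six-membered aromatic ring of carbon only, ortho to a large group. The earlier step of a 140-fold lower number from compound 1 to compound 3 (2.15 log units; beyond the scatter) set phenyl against hydrogen only, whereas this one shows that a five-membered aromatic ring with 1 hetero atom and 5 heavy atoms can stand where a six-membered ring group of 8 heavy atoms stood, with no difference beyond the scatter. Nothing measured here accounts for the two groups reading alike.

Going by these compounds, whether a non-aromatic group at this place, such as an amine or a carboxylic acid, would keep the number near that of compound 4 remains open. So does whether 1H-pyrrol-1-yl would read like the phenyl of compound 3 10 nM on that compound's own core.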